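Aminopyridine-isoxazole ethers: half-life notes before compound 4

The compounds below may be only part of what the source reports. "The series", "measured", "known", "first", "only" and "open" are said of these compounds alone.

Measured so far in an ADME assay on microsomes from liver (Homo sapiens) for metabolic stability, read by LC-MS, using NADPH, with stated times of 5 min and 45 min, tested at 1 uM; a higher number here means that the compound lasts longer, a lower number that the compound disappears faster:
compound 1 `Nc1ncccc1-c1cc(Cc2ccc(Cc3ccc(F)o3)cc2)no1` gives 0.24 h
compound 2 `Nc1ncccc1-c1cc(Cc2ccc(Oc3cccc(F)n3)cc2)no1` gives 0.717 h
compound 3 `Nc1ncccc1-c1cc(Cc2ccc(Oc3ccccn3)cc2)no1` gives 1.03 h

Compound 3 has the highest number of the three in this assay, but only compound 1 is clearly separated from it: a 4.3-fold higher number from compound 1 to compound 3 (0.63 log units; beyond the scatter). The remaining gap is a 1.4-fold higher number from compound 2 to compound 3 (0.16 log units; within the scatter), so no order between compound 2 and compound 3 can be claimed.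

Compound 4 `Nc1ncccc1-c1cc(Cc2ccc(OCc3ccncc3)cc2)no1` differs from compound 3 by (pyridin-4-yl)methyl in place of pyridin-2-yl on an oxygen on an aromatic ring. Among the measured compounds shown here, no measured step repeats this change. The steps that touch the same part of the molecule are a 3.0-fold higher number from compound 1 to compound 2 (0.48 log units; beyond the scatter) and a 4.3-fold higher number from compound 1 to compound 3 (0.63 log units; beyond the scatter), each exchanging the whole outer group on the aromatic carbon, and a 1.4-fold higher number from compound 2 to compound 3 (0.16 log units; within the scatter), which only removes a fluoro. They show that this region can shift the half-life by a modest amount, but give no guidance on the change from (pyridin-2-yl)oxy to (pyridin-4-yl)methoxy.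

Compound 4 is therefore expected to land within a modest step of compound 3, with a lower number thought somewhat more likely: a 1.7-fold lower number from compound 3 to compound 4 (0.23 log units; within the scatter). The estimate for compound 4 is 0.6 h, with a range from 0.25 h to 1.5 h.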

Compound 4, half-life: 0.288 h
For compound 4 the middle estimate is 2.1-fold (0.32 log units) above the measured one, within the range that was stated.
By their numbers in this assay, from the lowest: compounds 1 and 4 (each within the scatter of the next); then compounds 2 and 3 (each within the scatter of the next).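

In this assay the exchange on the oxygen gives a 3.6-fold lower number from compound 3 to compound 4 (0.55 log units; beyond the scatter) and, with 6-fluoropyridin-2-yl as the group replaced, a 2.5-fold lower number from compound 2 to compound 4 (0.40 log units; beyond the scatter) so the outer group on this oxygen can move the half-life beyond the scatter, which removal of the fluoro did not do. With a 1.2-fold higher number from compound 1 to compound 4 (0.08 log units; within the scatter) as the remaining step, no order can be claimed between these two compounds, although their outer groups differ. No measured property is available to explain these steps.

The step from (pyridin-2-yl)oxy to (pyridin-4-yl)methoxy alters the link and the pyridine attachment together, so which of the two changes accounts for the lower half-life stays open. Also open, from the compounds shown here alone, is how a longer chain or an amine on this oxygen would read in this assay on the same core.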